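This account rests on a few compounds, and the source may have more. Where it says the series, first, only, none or still open, it means among the compounds named here.

Compound 1 `COc1cccc(C(=O)n2c(-c3cn(C)c4ccccc34)nc3ccccc32)c1` and compound 2 `COc1ccc(C(=O)n2c(-c3cn(C)c4ccccc34)nc3ccccc32)cc1` share one core and differ only in the ring on the carbonyl carbon. In a functional assay on HepG2 cells (Homo sapiens) for inhibition, read by MTT assay, with a stated time of 24 h (on this read-out higher numbers stand for weaker inhibition of growth and lower numbers for stronger inhibition of growth), compound 1 gives 13600 nM, and compound 2 gives 15200 nM; the step of a 1.1-fold higher number from compound 1 to compound 2 (0.05 log units; within the scatter) sits inside the scatter. For the measured compounds named here, compound 2 thus shows the higher of the two numbers known so far, but its nearest neighbour, compound 1, lies so close that no order between them can be read.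

Compound 3 `COc1ccc(C(=O)n2c(-c3cn(C)c4ccccc34)nc3ccccc32)cc1OC` is the next member. Relative to compound 2 the change is methoxy in place of hydrogen on an aromatic carbon. Going by the values given here, the only measured step, from compound 1 to compound 2, moved one methoxy group from one position to another and did not move the number beyond the scatter. Among the compounds with values here, no step in which a second methoxy group enters an otherwise unchanged ring has been measured, so there is no direct precedent for the present change. On that basis a step of a 1.0-fold lower number from compound 2 to compound 3 (0.01 log units; within the scatter) is expected, no larger than the scatter. Compound 3 is therefore estimated at 15000 nM in this assay, within a range from 6000 nM to 40000 nM.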

Compound 3, concentration for 50% growth inhibition: 8400 nM
Estimate against measurement, compound 3: 1.8-fold (0.25 log units) above; measured number inside the range.
By their numbers in this assay, from the lowest: compounds 3, 1 and 2 (each within the scatter of the next).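

For the compounds shown here, compound 3 is the first case here in which a second methoxy group enters the ring on the carbonyl carbon, giving 3,4-dimethoxyphenyl, and it can be read against both compounds that carry a single methoxy group. In this assay the two steps are (a 1.8-fold lower number from compound 2 to compound 3 (0.26 log units; within the scatter)) and (a 1.6-fold lower number from compound 1 to compound 3 (0.21 log units; within the scatter)), and both lie within the scatter, so the added methoxy group, ortho to the methoxy group already present, gives no readable change from either starting point. What the earlier compounds showed for moving one methoxy group therefore now holds for adding a second one as well, though no evidence on the cause of these small steps is available.

The compounds shown leave open whether any change on this ring can move the number beyond the scatter, since all three carry only methoxy groups there. From the compounds shown here alone, an amine, a carboxylic acid or a longer alkoxy chain in this place, or a ring on the carbonyl carbon with no substituent at all, would test that question, and the effect of each remains unknown from these data.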